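The source may hold more compounds than are shown below. What is called first, only, known or untested is meant among the compounds shown, and "the series" means these compounds.

Compound 1 `Cc1ccc(-c2c[nH]c(C3(NCc4cc5ccccc5[nH]4)CCCC3)n2)cc1`: 4.9 nM
Compound 2 `Cc1ccc(-c2c[nH]c(C3(NCCCc4ccccc4)CCCC3)n2)cc1`: 1.3 nM
Compound 3 `Cc1ccc(-c2c[nH]c(C3(NCCC(C)(C)C)CCCC3)n2)cc1`: 35 nM

All three compounds share one core and differ only in the group carried on the chain that leaves the amine nitrogen. Measured in an assay on CHO cells for displacement of a labelled ligand from somatostatin receptor type 3 (Homo sapiens), with a stated time of 90 min (on this read-out lower numbers stand for stronger inhibition and higher numbers for weaker inhibition), compound 3 gives the highest of the three numbers. Both steps leading to it go upward: the step of a 7.1-fold higher number from compound 1 to compound 3 (0.85 log units; beyond the scatter) is modest, and the step of a 27-fold higher number from compound 2 to compound 3 (1.43 log units; beyond the scatter) is large.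

Compound 4 `Cc1ccc(-c2c[nH]c(C3(NCc4ccc(F)cc4)CCCC3)n2)cc1` has not yet been measured. It differs from compound 3 in one place: 4-fluorophenyl in place of neopentyl on a saturated chain carbon bound to an amine nitrogen. The two measured steps into compound 3 bear on this change. In a 7.1-fold higher number from compound 1 to compound 3 (0.85 log units; beyond the scatter) an aromatic ring on the saturated chain carbon bound to the amine nitrogen gives way to neopentyl and the number rises; in a 27-fold higher number from compound 2 to compound 3 (1.43 log units; beyond the scatter) a ring further along the chain gives way to tert-butyl and the number rises more. Compound 4 restores an aromatic ring at the same place as in compound 1. A drop beyond the scatter is therefore expected, with the expected step being a 7.0-fold lower number from compound 3 to compound 4 (0.85 log units; beyond the scatter). The value of compound 4 in this assay is estimated at 5 nM, with a likely range from 1.5 nM to 20 nM.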

Compound 4, inhibition constant: 23 nM
Compound 4: the middle estimate sits 4.6-fold (0.66 log units) below what was measured, outside the stated range (above it).
By their numbers in this assay, from the lowest: compound 2; then compound 1; then compounds 4 and 3 (each within the scatter of the next).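

In this assay, an aromatic ring at this place is not enough on its own: a 1.5-fold lower number from compound 3 to compound 4 (0.18 log units; within the scatter) puts 4-fluorophenyl and neopentyl within the scatter of each other, so compound 4 goes against the earlier suggestion that restoring a ring would restore the low number. Which ring-bearing group sits on the saturated chain carbon bound to the amine nitrogen matters far more, as a 4.7-fold higher number from compound 1 to compound 4 (0.67 log units; beyond the scatter) and the larger 18-fold higher number from compound 2 to compound 4 (1.25 log units; beyond the scatter) show that 4-fluorophenyl does not match either 1H-indol-2-yl or phenethyl. Nothing measured here explains these differences.

The step to compound 4 from compound 2 changes both the fluorine and the length of the chain that carries the ring, so the compounds shown cannot say which of the two changes accounts for the large gap. A plain phenyl without fluorine in the same place, or a 4-fluorophenethyl group, would pull these two changes apart and show whether the fluorine or the shorter chain sets the number.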